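The source may report more compounds than this note shows. Statements on the series, on what has been measured and on what is new or still open speak of the compounds shown alone.

Working notes on the series in a functional assay on HepG2 cells (Homo sapiens) for antiproliferative activity, read by MTT assay, with a stated time of 24 h; on this read-out higher numbers stand for weaker inhibition and lower numbers for stronger inhibition: compound 1 `O=[N+]([O-])c1cccc(CSc2nnc(-c3ccc4c(c3)OCCO4)n2-c2ccccc2)c1` gives 49300 nM, compound 2 `Clc1ccccc1CSc1nnc(-c2ccc3c(c2)OCCO3)n1-c1ccccc1` gives 970 nM, and compound 3 `COc1cccc(CSc2nnc(-c3ccc4c(c3)OCCO4)n2-c2ccccc2)c1` gives 35100 nM. Compound 3 stands with compound 1 at the high end of these three numbers, with a 1.4-fold lower number from compound 1 to compound 3 (0.15 log units; within the scatter), and the pair lies well above compound 2.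

The next structure is compound 4 `Fc1ccccc1CSc1nnc(-c2ccc3c(c2)OCCO3)n1-c1ccccc1`, reached by 2-fluorophenyl in place of 3-methoxyphenyl on a saturated chain carbon bound to a sulfur. Two measured steps at this place bear on it, a 51-fold lower number from compound 1 to compound 2 (1.71 log units; beyond the scatter) and a 36-fold higher number from compound 2 to compound 3 (1.56 log units; beyond the scatter), and both are large and turn on 2-chlorophenyl. Among the compounds with values here, no measured compound carries 2-fluorophenyl, so how much of that difference carries over is unknown.

The step expected in this assay is a 12-fold lower number from compound 3 to compound 4 (1.07 log units; beyond the scatter), a large one toward a lower number but probably short of the full distance to compound 2. The estimated value for compound 4 is 3000 nM, with an expected range of 700 nM to 15000 nM.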

Compound 4, half-maximal inhibitory concentration: 810 nM
For compound 4 the middle estimate is 3.7-fold (0.57 log units) above the measured one; measured number inside the range.
By their numbers in this assay, from the lowest: compounds 4 and 2 (each within the scatter of the next); then compounds 3 and 1 (each within the scatter of the next).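

In this assay, 2-fluorophenyl at this place on a saturated chain carbon bound to a sulfur gives a 43-fold lower number from compound 3 to compound 4 (1.64 log units; beyond the scatter) and a 61-fold lower number from compound 1 to compound 4 (1.78 log units; beyond the scatter) as well, so the large steps are no longer tied to 2-chlorophenyl alone. Fluoro in place of chloro on an aromatic carbon gives a 1.2-fold lower number from compound 2 to compound 4 (0.08 log units; within the scatter) and leaves compound 2 and compound 4 indistinguishable on this read-out, both well apart from compound 1 and compound 3. Nothing in hand bears on the cause of these differences.

The chloro and fluoro groups appear only as 2-chlorophenyl and 2-fluorophenyl, and the nitro and methoxy groups only as 3-nitrophenyl and 3-methoxyphenyl, so the effect of the group cannot be separated from that of its place on the ring. On these data alone, how an amine or a carboxylic acid on that phenyl ring, or a longer chain at the carbon bound to the sulfur, would read remains open.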